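Acid versus benzylamide on two dihydrofuran cores

This account rests on a few compounds, and the source may have more. Where it says the series, first, only, none or still open, it means among the compounds named here.

For the measured compounds named here, compound 2 `C=CC1=C(C(=O)NCc2ccccc2)C(c2ccc(F)cc2)OC1` is the only member of the set with a numerical reading: in a functional assay on QGY7701 cells (Homo sapiens) for cytotoxicity, read by MTT assay, with a stated time of 24 h (a higher number here means a weaker inhibitor, a lower number a stronger inhibitor), compound 2 gives 67600 nM. Compound 1 `C=CC1=C(C(=O)O)C(c2ccc(F)cc2)OC1` carries hydroxy in place of benzylamino on a carbonyl carbon. In this assay compound 1 returns > 100000 nM, which is a limit of the assay and not a number. The step is therefore known only as a floor, an at least 1.4-fold higher number from compound 2 to compound 1 (0.17 log units; that floor lies within the scatter). Compound 3 `C=CC1=C(C(=O)NCc2ccccc2)C(c2ccc(Cl)c(Cl)c2)OC1` keeps the benzylamide and differs from compound 2 in the core, 3,4-dichlorophenyl in place of 4-fluorophenyl on a saturated ring carbon. In this assay compound 3 gives > 100000 nM, again a limit of the assay rather than a number. Its step from compound 2 is likewise a floor, an at least 1.4-fold higher number from compound 2 to compound 3 (0.17 log units; that floor lies within the scatter). Two of the three readings thus rest at the limit of > 100000 nM in this assay, at which 2 of the 3 values shown sit.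

Compound 4 `C=CC1=C(C(=O)O)C(c2ccc(Cl)c(Cl)c2)OC1` is not yet measured. It stands to compound 3 as compound 1 stands to compound 2: hydroxy in place of benzylamino on a carbonyl carbon, with the place described in identical words, so it is the same change. That change, made once before, moved the reading to the limit. Compound 3 already sits at the limit of > 100000 nM in this assay, at which 2 of the 3 values shown sit, so there is no room for the same direction to show as a number. The step is expected to be a step that the limit leaves unreadable from compound 3 to compound 4. Compound 4 is expected to give 150000 nM in this assay, estimated between 80000 nM and 400000 nM, and most probably only a limit will be recorded.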

Compound 4, half-maximal inhibitory concentration: > 100000 nM
Compound 4 gave a limit, no number (the forecaster's own chance of this, stated with the estimate: 90%); the middle value does not contradict the limit.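

In this assay compound 4 gives > 100000 nM, a limit of the assay and not a number. Compound 3 and compound 4 both rest on limits, so no step between them can be read: the limit of > 100000 nM in this assay, at which 3 of the 4 values shown sit.

Left open is how far compound 1, compound 3 and compound 4 lie from one another, as only compound 2 carries a number.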